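Amide variation on the shared core: compound 3

The compounds below may be only part of what the source reports. "The series", "measured", "known", "first", "only" and "open" are said of these compounds alone.

Compound 1 `Cc1cccc(N(C)c2cc(Nc3cccc(C(=O)N(CC(C)C)CC(C)C)c3)ncn2)c1` and compound 2 `Cc1cccc(Oc2ccnc(N3CCN(C(=O)c4c(C)noc4C)CC3)n2)c1` have both been measured in an assay on isolated protein for inhibition of Ephrin type-B receptor 4 (Homo sapiens), read by HTRF, tested at 10 uM; a higher number here means more inhibition at the concentration tested (going by the name of the read-out), a lower number less inhibition. In this assay compound 1 gives 0% and compound 2 gives 0%; these two values lie within the scatter of each other, so compound 1 stands level with compound 2. Compound 3 `Cc1cccc(N(C)c2cc(Nc3cccc(C(=O)N4CCCC5CCCCC54)c3)ncn2)c1` is the next entry. It differs from compound 1 in one place: a group of 10 heavy atoms (9 carbon, 1 nitrogen; one six-membered non-aromatic ring of carbon only, one six-membered non-aromatic ring with 1 hetero atom) in place of a group of 9 heavy atoms (8 carbon, 1 nitrogen; no ring), on a carbonyl carbon. Within the data shown here, no step between measured compounds is available to size this change. Since compound 1 gives only 0% in this assay, the step of a number 3 percentage points higher from compound 1 to compound 3 (within the scatter) is expected to be none beyond the scatter. For compound 3 the expected value in this assay is 3%, with a range from -5% to 15%.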

Compound 3, a percentage reported as inhibition, at one concentration (the size of the read-out at that concentration, not a potency): 0%
The estimate for compound 3 lay 3 percentage points above the measured number; the measured number falls inside the stated range.
By their numbers in this assay, from the lowest: compounds 1, 2 and 3 (each within the scatter of the next).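

On the carbonyl carbon, putting the group with two six-membered non-aromatic rings in place of diisobutylamino gives no change at the digits printed from compound 1 to compound 3 (within the scatter) in this assay. Adding these rings to the amide therefore produces no inhibition beyond the scatter, so this position has yet to show any response to a change. No measurement available here explains this result.

With no step beyond the scatter, the compounds shown give no direction for this position. Going by these compounds, whether a morpholine or a benzylamine on the carbonyl carbon would give a readable inhibition remains open.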